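Removing the Fluorine of Compound 1: What to Expect

This account rests on a few compounds, and the source may have more. Where it says the series, first, only, none or still open, it means among the compounds named here.

Compound 1, `CCCCCCCCn1cc(/C=C/C(=O)c2ccc(NC(=O)CN3CCN(c4ccccc4F)CC3)cc2)nn1`: 68600 nM
Compound 2, `O=C(CN1CCC(Cc2ccccc2)CC1)Nc1ccc(C(=O)/C=C/c2cn(Cc3ccc(Br)cc3)nn2)cc1`: 54500 nM
Compound 3, `CC(C)(C)OC(=O)N1CCN(CC(=O)Nc2ccc(C(=O)/C=C/c3cn(Cc4ccc(Br)cc4)nn3)cc2)CC1`: 31000 nM

In a functional assay on MCF7 cells (Homo sapiens) for inhibition, read by MTT assay (a higher number here means a weaker inhibitor, a lower number a stronger inhibitor), compound 1 gives 68600 nM, the highest of the three numbers. Compound 2 gives 54500 nM, which lies within the scatter of compound 1. Compound 3 gives 31000 nM, a number beyond the scatter below that of compound 1.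

Compound 4, `CCCCCCCCn1cc(/C=C/C(=O)c2ccc(NC(=O)CN3CCN(c4ccccc4)CC3)cc2)nn1`, differs from compound 1 in one place: hydrogen in place of fluoro on an aromatic carbon. Among the measured compounds shown here, no measured pair shows this change, so nothing in the data anchors its size. In this assay a step of no size beyond the scatter is expected, in either direction. Compound 4 is therefore expected to give about 60000 nM, with a range from 25000 nM to 150000 nM. That estimate means a step of a 1.1-fold lower number from compound 1 to compound 4 (0.06 log units; within the scatter) is expected.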

Compound 4, half-maximal inhibitory concentration: 31900 nM
The estimate for compound 4 lay 1.9-fold (0.27 log units) above the measured number; low and high end bracket the measured number.
By their numbers in this assay, from the lowest: compounds 3, 4, 2 and 1 (each within the scatter of the next, the first and the last beyond it).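

In this assay, among the compounds shown here, the change from 2-fluorophenyl to phenyl gives a 2.2-fold lower number from compound 1 to compound 4 (0.33 log units; beyond the scatter) and is the first comparison here that isolates a single place. It shows that the fluoro on this aromatic carbon, ortho to a large group, is not required for the activity of the series, and that the number falls modestly without it. Nothing available explains this step. On these data alone, whether chloro, methoxy or an amine on this same carbon would lower the number further remains open.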